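Shortening the acid tail of compound 2

The source may report more compounds than this note shows. Statements on the series, on what has been measured and on what is new or still open speak of the compounds shown alone.

Of the compounds shown here, three have been measured in an assay on a protein complex (K562 cells) for inhibition of integrin alpha-5/beta-1 (Homo sapiens), with stated times of 30 min and 1 h; on this read-out higher numbers stand for weaker inhibition and lower numbers for stronger inhibition. Compound 1 `CC1=C(C(=O)NCc2ccc(N)cc2)C(C(C)C)N(C(=O)CC(=O)O)O1` gives 1050 nM, and compound 3 `C/C=C(\C(=O)NCC(=O)O)C(NCc1ccc(NC(=O)CN)cc1)C(C)C` gives 170 nM. Compound 2 `C/C=C(\C(=O)NCC(=O)O)C(C)NCc1ccc(N)cc1` gives 9800 nM, the highest of the three numbers, so on this read-out it is the weakest of the set, with the gap to compound 1 and the larger gap to compound 3 both beyond the usual scatter.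

Compound 4 `C/C=C(\C(=O)O)C(C)NCc1ccc(N)cc1` has not been measured. It differs from compound 2 in one place: hydroxy in place of (carboxymethyl)amino on a carbonyl carbon. The amide and its attached acid are gone, and a plain carboxylic acid now sits on the carbonyl carbon.

For the measured compounds named here, nothing among the measured compounds shows what this shortening does, since no pair of them differs in just this way. The expectation rests only on compound 2 being already the weakest and on the loss of the (carboxymethyl)amino group. A step of a 2.6-fold higher number from compound 2 to compound 4 (0.41 log units; beyond the scatter) is expected, toward a higher number and probably beyond the scatter. Compound 4 is therefore estimated at 25000 nM in this assay, with a plausible range from 6000 nM to 100000 nM.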

Compound 4, half-maximal inhibitory concentration: 19 nM
Estimate against measurement, compound 4: 1300-fold (3.12 log units) above; measured number below the stated range.
By their numbers in this assay, from the lowest: compound 4; then compound 3; then compound 1; then compound 2.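

In this assay, putting hydroxy in place of (carboxymethyl)amino on a carbonyl carbon gives a 520-fold lower number from compound 2 to compound 4 (2.71 log units; beyond the scatter). The (carboxymethyl)carbamoyl group of compound 2 is therefore not needed for inhibition here: with its 5 heavy atoms replaced by 1, and a plain carboxy left at this place, inhibition is far stronger, so this position responds strongly to what sits on the carbonyl carbon. No measurement available gives a reason for a step of this size.

The compounds shown do not tell how inhibition changes with other groups on the same carbonyl carbon, such as an amine, a methoxy group or a longer chain ending in a carboxylic acid, so it remains unclear whether the length of the tail or the loss of the amide matters more. Going by these compounds, it also remains open whether the same shortening would give a similar step on a compound with a different remainder, such as compound 3, which carries the same (carboxymethyl)carbamoyl group but differs from compound 2 elsewhere.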